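Adding a second methyl to compound 2

A few compounds are considered here, and "the series" means these few. Any claim that something is new, unique, unknown or untested is made for them only; others in the source may bear on it.

In a functional assay on AS49-RAW cells (Homo sapiens) for antiproliferative activity, read by sulforhodamine B assay, with a stated time of 48 h (on this read-out lower numbers stand for stronger inhibition and higher numbers for weaker inhibition), compound 2 `Cc1ccnc(NS(=O)(=O)c2ccc(N/C(S)=N\c3ccnc4cc(C(F)(F)F)ccc34)cc2)n1` gives 31000 nM. In this assay, going by the values given here, compound 1 `O=S(=O)(Nc1ncccn1)c1ccc(N/C(S)=N\c2ccnc3cc(C(F)(F)F)ccc23)cc1` gives 37800 nM, and the step of a 1.2-fold lower number from compound 1 to compound 2 (0.09 log units; within the scatter) leaves the two within the scatter of each other, so compound 2 stands on a par with the only other measured compound. Compound 3 `Cc1cc(C)nc(NS(=O)(=O)c2ccc(N/C(S)=N\c3ccnc4cc(C(F)(F)F)ccc34)cc2)n1` differs from compound 2 by methyl in place of hydrogen on an aromatic carbon. Among the compounds with values here, the one step that bears on this change, a 1.2-fold lower number from compound 1 to compound 2 (0.09 log units; within the scatter), stayed within the scatter, so no shift beyond the scatter is expected in this assay. Compound 3 is therefore estimated at 28000 nM, with a range of 12000 nM to 70000 nM, which corresponds to an expected 1.1-fold lower number from compound 2 to compound 3 (0.04 log units; within the scatter).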

Compound 3, half-maximal inhibitory concentration: 43400 nM
Compound 3: the middle estimate sits 1.6-fold (0.19 log units) below what was measured; the measured number falls inside the stated range.
By their numbers in this assay, from the lowest: compounds 2, 1 and 3 (each within the scatter of the next).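

In this assay, a second methyl on the ring gives the step (a 1.4-fold higher number from compound 2 to compound 3 (0.15 log units; within the scatter)), and two methyl groups taken together give the step (a 1.1-fold higher number from compound 1 to compound 3 (0.06 log units; within the scatter)). Going by these compounds alone, the position thus tolerates methyl in place of hydrogen, singly or on both carbons, with no shift beyond the scatter, which the single step from the earlier compounds could not show. No measurement on hand accounts for this result. As far as these compounds go, whether a methoxy, an amine or a longer chain in this place would shift the number beyond the scatter remains open.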